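Removing the methoxy group from compound 3

A few compounds are considered here, and "the series" means these few. Any claim that something is new, unique, unknown or untested is made for them only; others in the source may bear on it.

Three related compounds share a long chain capped by the same fluorinated amide, and they differ at the other end. In a functional assay on cells (Panel NCI-60 (60 carcinoma cell lines), Homo sapiens) for inhibition, read by colorimetric assay, with a stated time of 3 days (on this read-out higher numbers stand for weaker inhibition of growth and lower numbers for stronger inhibition of growth), compound 1 `COc1ccc(OC)c(NC(=O)CCCCCCNC(=O)C(O)(O)C(F)(F)F)c1` has no usable result, its entry reading "not determined" (no result reported). Compound 2 `O=C(CCCCCCNC(=O)C(O)(O)C(F)(F)F)Nc1ncc(-c2ccc(Br)cc2)s1` gives 930 nM, and compound 3 `COc1ccc2sc(NC(=O)CCCCCCNC(=O)C(O)(O)C(F)(F)F)nc2c1` gives 1230 nM. Within the data shown here, these two numbers lie within the scatter of each other, so compound 3 stands level with the only other measured compound.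

Compound 4 `O=C(CCCCCCNC(=O)C(O)(O)C(F)(F)F)Nc1nc2ccccc2s1` has hydrogen in place of methoxy on an aromatic carbon of compound 3 (hydrogen in place of methoxy on an aromatic carbon). Among the measured compounds shown here, no measured pair shows this change on its own, so any forecast is uncertain. Even so, compound 2 at 930 nM and compound 3 at 1230 nM have clearly different structures and still give matching numbers, which suggests that a smaller edit will shift little. No step beyond the scatter is expected in either direction, and the estimated change is a 1.1-fold higher number from compound 3 to compound 4 (0.06 log units; within the scatter). Compound 4 is expected at 1400 nM, with an estimated range from 600 nM to 3300 nM.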

Compound 4, concentration for 50% growth inhibition: 3390 nM
Beside the measured number, compound 4's estimate is 2.4-fold (0.38 log units) below it; the measured number lies above the stated range.
By their numbers in this assay, from the lowest: compounds 2 and 3 (each within the scatter of the next); then compound 4.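

In this assay, putting hydrogen in place of methoxy on this aromatic carbon brings a 2.8-fold higher number from compound 3 to compound 4 (0.44 log units; beyond the scatter) and therefore weaker inhibition of growth. The step is modest, but it shows that this position of the core is not indifferent to what it carries and that, of these two groups, methoxy goes with the stronger inhibition. The earlier compounds differ in more than one place and could not isolate this effect, and no measurement at hand accounts for the step.

From the compounds shown here alone, what remains open is whether the methoxy group itself matters or whether another group on the same carbon, such as a hydroxyl, an amine or a chlorine, would serve equally well. Also open, going by these compounds, is whether an ethoxy group, with its longer chain, would keep the level of compound 3.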